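This account rests on a few compounds, and the source may have more. Where it says the series, first, only, none or still open, it means among the compounds named here.

Measured in a functional assay on BMEC cells (Bos taurus) for antiproliferative activity; a lower number here means a stronger inhibitor, a higher number a weaker inhibitor:
compound 1 `COc1cc(/C=C\Cc2cc(O)c3ccoc3c2)cc(OC)c1OC`: 49 nM.
compound 2 `COc1cc(/C=C/Cc2cc(O)c3ccoc3c2)cc(OC)c1OC`: 27700 nM.
compound 3 `COc1cc(/C=C\Cc2cc(O)c3cc(-c4ccccc4)oc3c2)cc(OC)c1OC`: > 2000 nM, a limit and not a number.

Compound 1 holds the lower of the two actual numbers, and the value of compound 3 is a limit. Both measured steps away from compound 1 are large and go upward. The first is a 570-fold higher number from compound 1 to compound 2 (2.75 log units; beyond the scatter), which goes with the fact that compounds 1 and 2 differ only in the configuration as drawn. The second is an at least 40-fold higher number from compound 1 to compound 3 (1.61 log units; beyond the scatter), and it rests on (the limit of > 2000 nM in this assay, at which 1 of the 3 values shown sits).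

Compound 4 `COc1cc(/C=C\Cc2cc(OC)c3ccoc3c2)cc(OC)c1OC` changes compound 1 by methyl in place of hydrogen on an oxygen on an aromatic ring, that is, hydroxy to methoxy. For the measured compounds named here, no measured step touches this oxygen, so the evidence is indirect. Going by the values given here, the step of an at least 40-fold higher number from compound 1 to compound 3 (1.61 log units; beyond the scatter) shows only that one added group elsewhere on the aromatic core can cost much, and compound 1 has no measured step downward. A moderate rise is therefore expected, probably smaller than either measured step, though the uncertainty is wide.

The expected step is a 5.1-fold higher number from compound 1 to compound 4 (0.71 log units; beyond the scatter). For compound 4 the estimated value is 250 nM. The expected range for compound 4 runs from 50 nM to 2000 nM.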

Compound 4, half-maximal inhibitory concentration: 7500 nM
The estimate for compound 4 lay 30-fold (1.48 log units) below the measured number; measured number outside the range, above it.
By their numbers in this assay, from the lowest: compound 1; then compound 4; then compound 2.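

For the compounds shown here, the hydroxy group on the aromatic ring is now read directly for the first time: hydroxy to methoxy adds only one carbon, yet it gives a 150-fold higher number from compound 1 to compound 4 (2.18 log units; beyond the scatter) in this assay and so is not a tolerated change at this oxygen. This oxygen now joins the double-bond configuration and the aromatic carbon that carries phenyl in compound 3 as places where a single change away from compound 1 raises the number, and no step shown from compound 1 goes downward. Nothing shown gives a measured reason for this step.

The compounds shown leave open whether the rise follows the loss of the hydroxy hydrogen or the presence of the added methyl. An amine in place of the hydroxy group, or a longer chain such as ethyl on the same oxygen, would help to separate the two readings.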